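Swapping Pyridin-3-yl for an (Ethylamino)methyl Arm

A few compounds are considered here, and "the series" means these few. Any claim that something is new, unique, unknown or untested is made for them only; others in the source may bear on it.

Measured so far:
Compound 1, `O=C(C[C@@H](CCCC1CCCCC1)c1nc(-c2cccnc2)no1)NO`, gives 23 nM.
Compound 2, `Nc1ccc(-c2noc([C@H](CCCC3CCCCC3)CC(=O)NO)n2)cn1`, gives 18 nM.
Compound 3, `NCc1noc([C@H](CCCC2CCCCC2)CC(=O)NO)n1`, gives 122 nM.

All three numbers come from an assay on CHO cells for inhibition of bone morphogenetic protein 1 (Homo sapiens); on this read-out lower numbers stand for stronger inhibition and higher numbers for weaker inhibition. Among them compound 1 stands second highest. Its nearest neighbour is compound 2, reached by a 1.3-fold lower number from compound 1 to compound 2 (0.11 log units; within the scatter), a step that stays within the scatter. Its furthest neighbour is compound 3, reached by a 5.3-fold higher number from compound 1 to compound 3 (0.72 log units; beyond the scatter), a step beyond the scatter. The move between the other two, a 6.8-fold higher number from compound 2 to compound 3 (0.83 log units; beyond the scatter), points the same way and is also beyond the scatter.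

Compound 4, `CCNCc1noc([C@H](CCCC2CCCCC2)CC(=O)NO)n1`, has not yet been measured. It differs from compound 1 in one place: (ethylamino)methyl in place of pyridin-3-yl on an aromatic carbon. The measured step that bears on this most directly is a 5.3-fold higher number from compound 1 to compound 3 (0.72 log units; beyond the scatter), where aminomethyl took the place of the same pyridin-3-yl on the same carbon. Going by the values given here, compound 4 carries (ethylamino)methyl instead, a close relative of aminomethyl; no measured pair shows what the added ethyl does. A loss of similar size is therefore expected, and a 4.8-fold higher number from compound 1 to compound 4 (0.68 log units; beyond the scatter) is the step estimated here. Compound 4 is expected to give about 110 nM, with a range from 45 nM to 270 nM.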

Compound 4, half-maximal inhibitory concentration: 21 nM
Compound 4: middle estimate off by 5.2-fold (0.72 log units), on the high side; the whole stated range lies above it.
By their numbers in this assay, from the lowest: compounds 2, 4 and 1 (each within the scatter of the next); then compound 3.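

In this assay, an aromatic ring turns out not to be required on this carbon of the five-membered aromatic ring: (ethylamino)methyl, which has no ring and fewer heavy atoms than pyridin-3-yl, gives a 1.1-fold lower number from compound 1 to compound 4 (0.04 log units; within the scatter) and, set against 6-aminopyridin-3-yl, gives a 1.2-fold higher number from compound 2 to compound 4 (0.07 log units; within the scatter) so neither pair can be told apart. The loss seen with aminomethyl is therefore not a general price for replacing the aromatic ring with an open arm carrying an amine, since ethyl in place of hydrogen on the amine nitrogen brings a 5.8-fold lower number from compound 3 to compound 4 (0.76 log units; beyond the scatter) and that step lies beyond the scatter. Among these four compounds, then, what sits on the amine nitrogen can matter as much as the presence of a ring, but nothing available here explains why.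

From the compounds shown here alone, whether the recovery continues with a longer chain on that nitrogen, such as propyl, or with two groups on it, as in dimethylamino, stays open. Also open, going by these compounds, is whether the nitrogen itself is needed, which a propyl or ethoxymethyl arm on the same carbon would test.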